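A few compounds are considered here, and "the series" means these few. Any claim that something is new, unique, unknown or untested is made for them only; others in the source may bear on it.

Of the compounds shown here, three that share one core have so far been measured in an in vitro assay on 293T cells for displacement of a labelled ligand from prostaglandin D2 receptor 2 (Homo sapiens), read by scintillation counting, in the presence of a further agent that is not named here; on this read-out higher numbers stand for weaker inhibition and lower numbers for stronger inhibition. Compound 1 `COc1ccc(CC(=O)O)cc1-c1ccc(C(F)(F)F)cc1CN(C(=O)OCc1ccccc1)C1CCCC1` gives 53 nM. Compound 2 `COc1ccc(CC(=O)O)cc1-c1ccc(C(F)(F)F)cc1CNC(=O)OCc1ccccc1` gives 238 nM, the highest of the three numbers; its nearest neighbour is compound 1, and compound 3 lies furthest from it. Compound 3 `CCN(Cc1cc(C(F)(F)F)ccc1-c1cc(CC(=O)O)ccc1OC)C(=O)OCc1cc(F)cc(F)c1` gives 11 nM. Compound 3 differs from compound 2 in more than one place, so the two values can only be set side by side, without a single step between them. For the measured compounds named here, the one step that ends at compound 2 is a 4.5-fold higher number from compound 1 to compound 2 (0.65 log units; beyond the scatter).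

Compound 4 `COc1ccc(CC(=O)O)cc1-c1ccc(C(F)(F)F)cc1CN(C(=O)OCc1ccccc1)C1CC1` has not yet been measured. It differs from compound 2 by cyclopropyl in place of hydrogen on an amide-type nitrogen. This change runs in the opposite direction to the measured step from compound 1 to compound 2, which took a ring off the same nitrogen, though the ring that now enters is cyclopropyl rather than cyclopentyl. The measured step therefore bears directly on it and points to a lower number for compound 4, but a full return to the number of compound 1 is not assured. The expected step is a 2.6-fold lower number from compound 2 to compound 4 (0.42 log units; beyond the scatter), beyond the scatter, because a 4.5-fold higher number from compound 1 to compound 2 (0.65 log units; beyond the scatter) was itself beyond the scatter. Compound 4 is estimated to give 90 nM, with a range from 40 nM to 200 nM.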

Compound 4, half-maximal inhibitory concentration: 18 nM
Estimate against measurement, compound 4: 5.0-fold (0.70 log units) above; the whole stated range lies above it.
By their numbers in this assay, from the lowest: compounds 3 and 4 (each within the scatter of the next); then compound 1; then compound 2.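

In this assay, for the compounds shown here, the group on the amide-type nitrogen has a wider effect than the earlier pair could show: cyclopropyl in place of hydrogen gives a 13-fold lower number from compound 2 to compound 4 (1.12 log units; beyond the scatter), a large step, whereas the one earlier step at this position, the loss of cyclopentyl, was modest at a 4.5-fold higher number from compound 1 to compound 2 (0.65 log units; beyond the scatter). The new compound also shows that the two rings are not interchangeable here, since cyclopropyl in place of cyclopentyl gives a 2.9-fold lower number from compound 1 to compound 4 (0.47 log units; beyond the scatter), a modest step but one beyond the scatter, so the result depends on which ring is present and not only on a ring being there. Nothing available accounts for either step or for the difference between the two rings.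

The compounds shown leave open how the number changes across other groups on this nitrogen, such as a cyclobutyl ring, an isopropyl group or a longer chain like n-butyl, and therefore whether the trend between the two rings extends to any other group. Compound 3 differs from compound 4 in more than one place, so it cannot show whether cyclopropyl would keep its effect alongside a different group on the rest of the molecule.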